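Nitro substitution on the shared core of compound 3

The source may hold more compounds than are shown below. What is called first, only, known or untested is meant among the compounds shown, and "the series" means these compounds.

Three compounds have numbers in a functional assay on HCT-116 cells (Homo sapiens) for cytotoxicity, read by MTT assay; a higher number here means a weaker inhibitor, a lower number a stronger inhibitor. Compound 1 `O=[N+]([O-])c1ccc2[nH]c(CN3CCN(c4ccc(F)cc4)CC3)nc2c1` gives 14000 nM. Compound 2 `CCOC(=O)c1c(NCc2nc3ccccc3[nH]2)sc2c1CCCCC2` gives 31000 nM. Compound 3 `CC1=NN(Cc2nc3ccccc3[nH]2)C(=O)C1` gives 42000 nM, the highest number of the three; its gap to compound 2 lies within the scatter, its gap to compound 1 beyond it. For the measured compounds named here, no pair of measured compounds differs in only one place, so the series carries no direct reading on any single change.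

Compound 4 `CC1=NN(Cc2nc3cc([N+](=O)[O-])ccc3[nH]2)C(=O)C1` differs from compound 3 in one place: nitro in place of hydrogen on an aromatic carbon. Compound 1 also carries a nitro group on its shared core and gives the lowest of the three numbers, but it differs from compound 3 in several places at once and cannot be read as a step. The expectation for the change is a small lowering of the number, near the edge of the scatter, estimated as a 1.7-fold lower number from compound 3 to compound 4 (0.23 log units; within the scatter). Compound 4 is accordingly expected to give 25000 nM, in a range from 9000 nM to 70000 nM.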

Compound 4, half-maximal inhibitory concentration: 200000 nM
Compound 4: middle estimate off by 8.0-fold (0.90 log units), on the low side, outside the stated range (above it).
By their numbers in this assay, from the lowest: compound 1; then compounds 2 and 3 (each within the scatter of the next); then compound 4.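

In this assay, for the compounds shown here, nitro in place of hydrogen on an aromatic carbon of the shared core gives a 4.8-fold higher number from compound 3 to compound 4 (0.68 log units; beyond the scatter) and so provides the first direct reading on a single change: with the rest of compound 3 held constant, this substitution moves toward weaker inhibition. Going by these compounds alone, compound 1 also carries nitro on its core, but it differs from compound 3 in several places, so its number has no bearing on this step. Nothing available accounts for the size or direction of the step.

Going by these compounds, it remains open whether the change is specific to nitro or would also appear with an amine, a methoxy group or a fluorine on the same carbon. On these data alone, it is equally open whether nitro would move the number the same way on the core of compound 2.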